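Swapping a para-cyclopropyloxy for bromo in compound 3

The source may hold more compounds than are shown below. What is called first, only, known or untested is meant among the compounds shown, and "the series" means these compounds.

Measured compounds:
Compound 1 `CC(C)[C@@H](CC(=O)O)NC(=O)[C@@H]1CCCN1S(=O)(=O)c1cc(Cl)cc(Cl)c1`: 8.9 nM
Compound 2 `O=C(O)C[C@@H](NC(=O)[C@@H]1CCCN1S(=O)(=O)c1cc(Cl)cc(Cl)c1)c1ccc(O)cc1`: 0.74 nM
Compound 3 `O=C(O)C[C@@H](NC(=O)[C@@H]1CCN1S(=O)(=O)c1cc(Cl)cc(Cl)c1)c1ccc(OC2CC2)cc1`: 0.31 nM

In an assay on RPMI-8866 cells for inhibition of integrin alpha-4/beta-1 (Homo sapiens) (on this read-out higher numbers stand for weaker inhibition and lower numbers for stronger inhibition), compound 3 has the lowest number of the three, below compound 2 and well below compound 1. Among the compounds with values here, the step from compound 1 to compound 2 is the only single change that has been measured: a 12-fold lower number from compound 1 to compound 2 (1.08 log units; beyond the scatter). That change sits on the saturated chain carbon of the shared core, not on the aromatic ring, so it says little about what happens further out.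

Compound 4 `O=C(O)C[C@@H](NC(=O)[C@@H]1CCN1S(=O)(=O)c1cc(Cl)cc(Cl)c1)c1ccc(Br)cc1` differs from compound 3 at the ring end: bromo in place of cyclopropyloxy on an aromatic carbon. Within the data shown here, no measured pair touches this position, and compound 2 and compound 3 differ in two places at once, so their two values only show that both are far stronger than compound 1. With nothing to lean on, the expectation is a small shift at most, within or just beyond the scatter, the direction open. Compound 4 is therefore expected to give 0.6 nM in this assay, between 0.2 nM and 2 nM, which means an expected 1.9-fold higher number from compound 3 to compound 4 (0.29 log units; within the scatter).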

Compound 4, half-maximal inhibitory concentration: 2.1 nM
Compound 4: the middle estimate sits 3.5-fold (0.54 log units) below what was measured; the measured number lies above the stated range.
By their numbers in this assay, from the lowest: compound 3; then compound 2; then compound 4; then compound 1.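

Within the data shown here, this is the first single change measured on the aromatic ring, and it shows that the group at this place matters: in this assay bromo in place of cyclopropyloxy gives a 6.8-fold higher number from compound 3 to compound 4 (0.83 log units; beyond the scatter) and so lies beyond the usual scatter. The step swaps a group of several heavy atoms, with an oxygen and a three-membered ring, for a single bromine, and the compound carrying cyclopropyloxy has the lower number. Nothing available here explains this difference.

A single pair cannot separate the part played by the oxygen from that played by the three-membered ring. Methoxy, which keeps the oxygen without the ring, or a plain cyclopropyl group, which keeps the ring without the oxygen, would be needed on the same aromatic carbon to pull these two apart.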